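The source may hold more compounds than are shown below. What is called first, only, known or untested is meant among the compounds shown, and "the series" means these compounds.

Working notes on the sulfonyl pyrazoline series. The shared core carries a dimethylaminophenyl on one side, a triazolylphenyl on the other, and an arylsulfonyl whose para substituent is the only point of variation. Compound 1 `CN(C)c1ccc(C2CC(c3ccc(-n4cncn4)cc3)=NN2S(=O)(=O)c2ccc(F)cc2)cc1` bears fluoro there; in a functional assay on NCI-H1975 cells (Homo sapiens) for inhibition, read by sulforhodamine B assay, tested at 10 uM (a lower number here means less inhibition, a higher number more inhibition at the concentration tested (going by the name of the read-out)), compound 1 gives -0.5%. Compound 2 `CN(C)c1ccc(C2CC(c3ccc(-n4cncn4)cc3)=NN2S(=O)(=O)c2ccc(C#N)cc2)cc1` bears cyano, and in this assay compound 2 gives 22.6%. Among the measured compounds shown here, the single measured step is a number 23.1 percentage points higher from compound 1 to compound 2 (beyond the scatter), so compound 2 stands highest of the two numbers, with compound 1 beyond the scatter below it.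

Compound 3 `CN(C)c1ccc(C2CC(c3ccc(-n4cncn4)cc3)=NN2S(=O)(=O)c2ccc(OC(F)(F)F)cc2)cc1` is the next point on the same position. Relative to compound 2 the change is trifluoromethoxy in place of cyano on an aromatic carbon. For the measured compounds named here, no measured step swaps cyano for trifluoromethoxy; the only step known is the fluoro-to-cyano one, and it does not read directly onto this exchange. Both neighbours of compound 3 on this position sit within a modest band, so the step of a number 10.6 percentage points lower from compound 2 to compound 3 (beyond the scatter) is expected to be small, with a wide range. For compound 3 the value in this assay is estimated at 12%, between -8% and 32%.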

Compound 3, a percentage reported as inhibition, at one concentration (the size of the read-out at that concentration, not a potency): 11.1%
The estimate for compound 3 lay 0.9 percentage points above the measured number; the range from low to high includes it.
By their numbers in this assay, from the lowest: compound 1; then compound 3; then compound 2.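

In this assay trifluoromethoxy takes a middle place at this position: the exchange for cyano gives a number 11.5 percentage points lower from compound 2 to compound 3 (beyond the scatter) and the exchange for fluoro gives a number 11.6 percentage points higher from compound 1 to compound 3 (beyond the scatter) and so all three groups now stand apart from one another, with the order fluoro, trifluoromethoxy, cyano. The position therefore gives graded numbers rather than a single jump between two levels, and compound 2 remains the highest of the three. Going from cyano, 2 heavy atoms, to trifluoromethoxy, 5 heavy atoms, lowers the number, and no measurement is available that explains the order of the three groups.

From the compounds shown here alone, whether any group at this position can go beyond compound 2 stays open, since an amine, a carboxylic acid or a longer alkyl chain in place of these three groups would extend the comparison well past the present set. These are also readings at one concentration, so they leave open how the three compounds would compare in potency.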